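Vinyl to ethyl on a diyne chain: cytotoxicity expectation

The source may hold more compounds than are shown below. What is called first, only, known or untested is meant among the compounds shown, and "the series" means these compounds.

Measured so far:
- compound 1 `C=CCCCCCC#CC#CCO`: 10.8 ug/mL
- compound 2 `C=CCCCCCC#CC#CC(O)CC(C)=O`: 3.87 ug/mL
- compound 3 `C=CCCCCCCCC#CC#CCOCC(=O)O`: 4.96 ug/mL

In a functional assay on XF498 cells (Homo sapiens) for cytotoxicity (a lower number here means that less compound is needed, a higher number that more compound is needed for the effect), compound 2 shows the lowest number of the three. Compound 3 sits within the scatter of it, while compound 1 lies farther off, a step recorded as a 2.8-fold lower number from compound 1 to compound 2 (0.45 log units; beyond the scatter), which came with 2-oxopropyl in place of hydrogen on a saturated chain carbon bound to an oxygen on a saturated carbon and a triple-bonded carbon.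

Compound 4 `CCCCCCCC#CC#CC(O)CC(C)=O` differs from compound 2 by ethyl in place of vinyl on a saturated chain carbon, five bonds along the chain from a triple-bonded carbon. Within the data shown here, no measured pair tests this change; the only recorded step concerns a different part of the chain. With nothing to point either way, the expected step of a 1.0-fold higher number from compound 2 to compound 4 (0.00 log units; within the scatter) is none beyond the scatter. Compound 4 is therefore estimated at 3.9 ug/mL, within 2 ug/mL to 7.8 ug/mL.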

Compound 4, concentration for half-maximal effect: 3.7 ug/mL
Estimate against measurement, compound 4: 1.1-fold (0.02 log units) above; the range from low to high includes it.
By their numbers in this assay, from the lowest: compounds 4, 2 and 3 (each within the scatter of the next); then compound 1.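

In this assay, ethyl in place of vinyl on this saturated chain carbon leaves the number within the scatter (a 1.0-fold lower number from compound 2 to compound 4 (0.02 log units; within the scatter)). Among these compounds, this is the first measured pair to test this position, and here the double bond of the vinyl group can go without a shift beyond the scatter. No measurement at hand explains this result.

From the compounds shown here alone, whether a longer chain, an amine or a carboxylic acid at this position would shift the number remains open. So does whether the same change would behave alike in compound 1, which lacks the 2-oxopropyl group.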